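Dropping One Methoxy Group from Compound 1

The source may report more compounds than this note shows. Statements on the series, on what has been measured and on what is new or still open speak of the compounds shown alone.

For the measured compounds named here, in a functional assay on HMEC-1 cells (Homo sapiens) for antiproliferative activity, read by cell counting, with a stated time of 4 days (a lower number here means a stronger inhibitor, a higher number a weaker inhibitor), compound 1 (`COc1ccc(Oc2ccccc2NC(C)=C2C(=O)CC(c3ccccc3)CC2=O)cc1OC`) gives 140 nM and stands level with compound 3 (`CC(Nc1ccccc1Oc1ccc(C(C)O)cc1)=C1C(=O)CC(c2ccccc2)CC1=O`) at 140 nM as its value, the two together holding the highest of the three numbers known so far. Compound 2 (`COc1cc(Oc2ccccc2NC(C)=C2C(=O)CC(c3ccccc3)CC2=O)ccc1N`) lies lower, with 29 nM as its value.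

Compound 4 (`COc1cccc(Oc2ccccc2NC(C)=C2C(=O)CC(c3ccccc3)CC2=O)c1`) has not yet been measured. It differs from compound 1 by hydrogen in place of methoxy on an aromatic carbon in one place, hydrogen in place of methoxy on an aromatic carbon, which turns 3,4-dimethoxyphenyl into 3-methoxyphenyl.

Going by the values given here, two measured steps bear on this. Exchanging the same methoxy group for amino gave a 4.8-fold lower number from compound 1 to compound 2 (0.68 log units; beyond the scatter) as a modest change, so this group's replacement can move the number. Exchanging the whole 3,4-dimethoxyphenyl for 4-(1-hydroxyethyl)phenyl gave no change at the digits printed from compound 1 to compound 3 (within the scatter) and shows that a larger exchange need not move it. Among the compounds with values here, neither step removes a group without putting another in its place, so the data offer no direct precedent. With no amino entering, the shift seen for compound 2 is not expected to carry over.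

The expected result is a 1.1-fold higher number from compound 1 to compound 4 (0.03 log units; within the scatter) as a step, which would stay within the scatter. Compound 4 is estimated at 150 nM with an expected range from 60 nM to 380 nM in this measurement.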

Compound 4, half-maximal inhibitory concentration: 59 nM
Compound 4: middle estimate off by 2.5-fold (0.41 log units), on the high side; the measured number lies below the stated range.
By their numbers in this assay, from the lowest: compound 2; then compound 4; then compounds 1 and 3 (each within the scatter of the next).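

In this assay, removing the methoxy group that sits ortho to a methoxy group and para to a large group gives a 2.4-fold lower number from compound 1 to compound 4 (0.38 log units; beyond the scatter), so a lower number at this position does not require a new group to enter, and this methoxy group is not needed to hold the number where compound 1 has it. Hydrogen at the same place still falls short of amino, with a 2.0-fold higher number from compound 2 to compound 4 (0.31 log units; beyond the scatter), which ranks the three groups seen there as amino, then hydrogen, then methoxy, each step beyond the scatter; the exchange of whole aryl groups, which left no visible change at compound 1, also separates once this methoxy group is gone, with a 2.4-fold lower number from compound 3 to compound 4 (0.38 log units; beyond the scatter). No measurement among those shown accounts for why the number falls when this methoxy group leaves.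

The compounds shown leave open whether a fluorine atom, a hydroxyl group or an ethoxy group at this place would sit nearer to amino or to methoxy. They also leave open what amino would give without the remaining methoxy group, and whether the methoxy group still present in compound 4 contributes anything itself.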